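A few compounds are considered here, and "the series" means these few. Any claim that something is new, unique, unknown or untested is made for them only; others in the source may bear on it.

Measured in an assay on HEK293 cells for positive allosteric modulation of metabotropic glutamate receptor 2 (Rattus norvegicus), read by thallium flux, with a stated time of 2.5 min; on this read-out lower numbers stand for an effect already at smaller amounts and higher numbers for an effect only at larger amounts of compound:

compound 1 `Cc1c(OCCCCOc2ccc(C(=O)O)cc2)ccc(C(=O)CC2CCCC2)c1O`, 824 nM
compound 2 `Cc1c(OCCCCOc2ccc(C(=O)O)cc2)ccc(C(=O)CC2CCCC2)c1C`, "not determined" (no result reported)
compound 3 `Cc1c(OCCCCOc2ccc(C(=O)O)cc2)ccc(C(=O)CC(C)C)c1O`, 122 nM

Among the two numbers available, compound 1 stands highest; its nearest neighbour is compound 3, reached by the step of a 6.8-fold lower number from compound 1 to compound 3 (0.83 log units; beyond the scatter), which comes from isopropyl in place of cyclopentyl on a saturated chain carbon bound to a carbonyl carbon. For compound 2 no single number was reported.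

Compound 4 `Cc1c(OCCCCOc2ccc(C(=O)O)c(Cl)c2)ccc(C(=O)CC2CCCC2)c1O` differs from compound 1 by chloro in place of hydrogen on an aromatic carbon, at a position ortho to a carboxy group and meta to a large group, so that the 4-carboxyphenyl end of compound 1 becomes 4-carboxy-3-chlorophenyl. For the measured compounds named here, none of the measured steps bears on this change: the only step available, from compound 1 to compound 3, alters the chain on the carbonyl side of the shared core and leaves the carboxyphenyl end untouched. Going by the values given here, there is thus no measured precedent for a chloro entering at this place, and the expectation for compound 4 is a step of a 1.0-fold lower number from compound 1 to compound 4 (0.01 log units; within the scatter), that is, none beyond the scatter. Compound 4 is accordingly estimated at 800 nM, within a range of 300 nM to 2200 nM.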

Compound 4, half-maximal effective concentration: 510 nM
For compound 4 the middle estimate is 1.6-fold (0.20 log units) above the measured one; low and high end bracket the measured number.
By their numbers in this assay, from the lowest: compound 3; then compounds 4 and 1 (each within the scatter of the next).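

In this assay, for the compounds shown here, the earlier compounds differed only on the carbonyl side of the shared core, whereas this result gives the first reading at the carboxyphenyl end, at the place ortho to a carboxy group and meta to a large group. Chloro in place of hydrogen on this aromatic carbon gives a 1.6-fold lower number from compound 1 to compound 4 (0.21 log units; within the scatter) and so no change that can be told apart from repeated measurement, while the chain change gives a 6.8-fold lower number from compound 1 to compound 3 (0.83 log units; beyond the scatter) and remains the only step shown beyond the scatter. Nothing measured here offers a reason for this result.

The compounds shown leave open how fluoro, methyl or methoxy would read at this same place. They also leave open whether chloro here would read the same on the isopropyl chain of compound 3.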